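Glucagon receptor binding: a chlorophenyl in place of fluorophenyl

A few compounds are considered here, and "the series" means these few. Any claim that something is new, unique, unknown or untested is made for them only; others in the source may bear on it.

Measured compounds:
Compound 1 `C[C@H](c1ccc(C(=O)NCCC(=O)O)cc1)N1C(=O)C(c2cccc(OC(F)(F)F)c2)=N[C@]12CC[C@@H](C(C)(C)C)CC2`: 330 nM
Compound 2 `CC1(CC[C@H](c2ccc(C(=O)NCc3nn[nH]n3)cc2)N2C(=O)C(c3cc(Cl)cc(Cl)c3)=N[C@]23CC[C@@H](C(C)(C)C)CC3)CC1`: 17 nM
Compound 3 `C[C@H](c1ccc(C(=O)NCCC(=O)O)cc1)N1C(=O)C(c2ccccc2F)=N[C@]12CC[C@@H](C(C)(C)C)CC2`: 1100 nM

In an assay on CHO cells for displacement of a labelled ligand from Glucagon receptor (Homo sapiens), read by scintillation counting, with a stated time of 60 min (on this read-out lower numbers stand for stronger inhibition and higher numbers for weaker inhibition), compound 3 gives 1100 nM, the highest of the three numbers; compound 1 gives 330 nM and compound 2 gives 17 nM, both of them lower and both beyond the scatter from compound 3. Compound 4 `C[C@H](c1ccc(C(=O)NCCC(=O)O)cc1)N1C(=O)C(c2cccc(Cl)c2)=N[C@]12CC[C@@H](C(C)(C)C)CC2` has not yet been measured in this assay . It differs from compound 3 in one place: 3-chlorophenyl in place of 2-fluorophenyl on a carbon with a double bond to nitrogen.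

One measured step speaks to this change. Going a 3.3-fold higher number from compound 1 to compound 3 (0.52 log units; beyond the scatter), so the 3-(trifluoromethoxy)phenyl group is linked to the lower number and the 2-fluorophenyl group to the higher one. Among the compounds with values here, compound 2, which carries a 3,5-dichlorophenyl group together with a different side chain, gives the lowest number of all, but no single step connects it to compound 3.

Since the step from compound 1 to compound 3 is a 3.3-fold higher number from compound 1 to compound 3 (0.52 log units; beyond the scatter), the return toward a 3-substituted phenyl in compound 4 is expected to lower the number by a similar amount, that is a 4.4-fold lower number from compound 3 to compound 4 (0.64 log units; beyond the scatter). Compound 4 is therefore estimated at 250 nM, with a range from 80 nM to 800 nM.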

Compound 4, half-maximal inhibitory concentration: 130 nM
Beside the measured number, compound 4's estimate is 1.9-fold (0.28 log units) above it; the range from low to high includes it.
By their numbers in this assay, from the lowest: compound 2; then compound 4; then compound 1; then compound 3.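

In this assay, replacing 2-fluorophenyl with 3-chlorophenyl on the carbon with a double bond to nitrogen gives an 8.5-fold lower number from compound 3 to compound 4 (0.93 log units; beyond the scatter), so this position responds clearly to a change of aryl group while the rest of the molecule stays the same. Within the data shown here, the second step, a 2.5-fold lower number from compound 1 to compound 4 (0.40 log units; beyond the scatter), adds a comparison the earlier compounds could not give: the substituent changes from trifluoromethoxy to chloro on an aromatic carbon of the phenyl group, and the number still moves beyond the scatter, so the 3-chlorophenyl compound reads lowest among the three compounds sharing this side chain and core. No available evidence accounts for either step.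

The step from 2-fluorophenyl to 3-chlorophenyl changes both the halogen and where it sits, and a 3-fluorophenyl or a 2-chlorophenyl group would be needed to separate these two contributions. From the compounds shown here alone, it also remains open how a 3-methylphenyl group, or the 3,5-dichlorophenyl group of compound 2, would read on the side chain of compound 4.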